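The source may hold more compounds than are shown below. What is called first, only, known or untested is meant among the compounds shown, and "the series" means these compounds.

Among the compounds with values here, in a functional assay on HeLa cells (Homo sapiens) for cytotoxicity, read by neutral red uptake, with a stated time of 3 days (a higher number here means a weaker inhibitor, a lower number a stronger inhibitor), compound 2 `CN(C)CCCC(=O)OCc1c(F)c(N)c2c(=O)cc(-c3ccc(N)c(F)c3)oc2c1F` gives 4500 nM, the only actual number so far. Compound 1 `C[S+]([O-])c1c(F)c(N)c2c(=O)cc(-c3ccc(N)c(F)c3)oc2c1F` gives > 100000 nM in this assay, which is a limit of the assay and not a number. The step of an at least 22-fold lower number from compound 1 to compound 2 (1.34 log units; beyond the scatter) is therefore bounded on one side only, as shown by the limit of > 100000 nM in this assay, at which 1 of the 2 values shown sits. Compound 3 `NCc1c(F)c(N)c2c(=O)cc(-c3ccc(N)c(F)c3)oc2c1F` carries amino in place of ((3-(dimethylamino)propyl)carbonyl)oxy on a saturated chain carbon bound to an aromatic carbon; the same difference, cut one bond further out, reads (((3-(dimethylamino)propyl)carbonyl)oxy)methyl to aminomethyl. Within the data shown here, no measured step bears directly on this change: the single step recorded swaps a different group on an aromatic carbon, and its size is known only as a lower bound. A step of a 1.8-fold higher number from compound 2 to compound 3 (0.25 log units; within the scatter) is expected, most likely within the scatter or modestly toward a higher number. Compound 3 is estimated at 8000 nM, with a range of 2000 nM to 40000 nM.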

Compound 3, half-maximal inhibitory concentration: 8800 nM
Compound 3: middle estimate off by 1.1-fold (0.04 log units), on the low side, within the range that was stated.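

In this assay, the step of a 2.0-fold higher number from compound 2 to compound 3 (0.29 log units; within the scatter) shows that the position on a saturated chain carbon bound to an aromatic carbon accepts either amino or the much larger ((3-(dimethylamino)propyl)carbonyl)oxy, with the two compounds lying within the scatter of each other. The step of an at least 11-fold lower number from compound 1 to compound 3 (1.05 log units; beyond the scatter) shows that the small aminomethyl group, like the long chain of compound 2, stands clearly apart from the group on the aromatic carbon of compound 1. Compound 1 gives > 100000 nM, which is a limit of the assay and not a number, so this step too is bounded on one side only: the limit of > 100000 nM in this assay, at which 1 of the 3 values shown sits.

From the compounds shown here alone, whether a hydroxymethyl, a plain methyl or a carboxylic acid at this place would stay level with aminomethyl remains open. Going by these compounds, the true size of both steps from compound 1 also remains open.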